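The compounds below may be only part of what the source reports. "The series", "measured", "known", "first", "only" and "open" are said of these compounds alone.

Going by the values given here, compound 2 `c1ccc2c(c1)CC(c1nc3ccc(-c4cn[nH]c4)cc3[nH]1)CO2` is the only compound here with a number: in an assay on cells for inhibition of Rho-associated protein kinase 2 (Homo sapiens) (a lower number here means a stronger inhibitor, a higher number a weaker inhibitor), compound 2 gives 86 nM. Compound 1 `Cc1[nH]ncc1-c1ccc2nc(C3COc4ccccc4C3)[nH]c2c1` shares the same core, but in this assay compound 1 has "not determined" (no result reported), so nothing can be compared. Compound 3 `c1ccc2c(c1)CC(c1nc3ccc(-c4ccncc4)cc3[nH]1)CO2` differs from compound 2 in one place: pyridin-4-yl in place of 1H-pyrazol-4-yl on an aromatic carbon. Among the compounds with values here, with no measured step of this kind to lean on, the expectation is a small loss of potency, at the edge of the usual scatter, expressed as a 1.7-fold higher number from compound 2 to compound 3 (0.24 log units; within the scatter). Compound 3 is therefore estimated at 150 nM in this assay, within a range from 40 nM to 600 nM.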

Compound 3, half-maximal inhibitory concentration: < 6 nM
Compound 3 gave a limit, no number; the forecaster's own chance of this, stated with the estimate: 5%; at least 25-fold (1.39 log units) between middle value and limit.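

Going by these compounds alone, the first measured step at this aromatic carbon shows that the position is highly sensitive in this assay: pyridin-4-yl in place of 1H-pyrazol-4-yl gives an at least 14-fold lower number from compound 2 to compound 3 (1.15 log units; beyond the scatter). The ring size, the hetero atoms and the hydrogen-bond donor count all change in this single swap, so the step cannot separate them. The value of compound 3 is a limit and not a number, so the size of the step is a bound too: the limit of < 6 nM in this assay, at which 1 of the 3 values shown sits.

Still open, from the compounds shown here alone, is how a phenyl or a pyridin-3-yl group on this carbon would compare in this assay. Either would help show which part of the change matters.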